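The compounds below may be only part of what the source reports. "The series", "measured", "known", "first", "only" and "open" are said of these compounds alone.

In a functional assay on HepG2 cells (Homo sapiens) for cytotoxicity, with a stated time of 72 h (a higher number here means that more compound is needed for the effect, a lower number that less compound is needed), three compounds have been tested so far: compound 1 `C=C[C@@](C)(/C=C/c1ccc(O)c(/C=C/C(=O)O)c1)CCC=C(C)C`, compound 2 `C=C[C@@](C)(/C=C/c1ccc(O)c(/C=C(\C)C(=O)OCC)c1)CCC=C(C)C` and compound 3 `CCOC(=O)/C(C)=C/c1cc(/C=C/[C@](C)(/C=C/c2ccc(OC)cc2)CCC=C(C)C)ccc1O`. Compound 1 gives > 52000 nM, which is a limit of the assay and not a number. Compound 2 gives > 52000 nM, again a limit. Compound 3 gives > 52000 nM, also a limit. The whole set therefore stands at the limit of > 52000 nM in this assay, at which 3 of the 3 values shown sit.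

Compound 4 `COc1ccc(/C=C/[C@@](C)(/C=C/c2ccc(O)cc2)CCC=C(C)C)cc1` comes from compound 3 through one change, hydrogen in place of 2-(ethoxycarbonyl)prop-1-en-1-yl on an aromatic carbon.

Within the data shown here, two measured steps bear on this. The one that also alters this substituent is a step that the two limits leave unreadable from compound 1 to compound 2, and the other is a step that the two limits leave unreadable from compound 2 to compound 3. Neither has a readable size, so no measured size can be carried over. Among the measured compounds shown here, with every compound so far at the limit, no clear move is expected in this assay, and a reported limit is the likeliest result. The expected step, an at least 1.0-fold lower number from compound 3 to compound 4 (0.01 log units; that floor lies within the scatter), is only an estimate. For compound 4 the estimated value is 50000 nM, with an expected range from 20000 nM to 120000 nM.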

Compound 4, half-maximal effective concentration: > 52000 nM
Compound 4 was reported as a limit (the forecaster's own chance of this, stated with the estimate: 70%); middle value at least 1.0-fold (0.01 log units) from the limit.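

In this assay compound 4 gives > 52000 nM, a limit and not a number. Compound 3 also stands at a limit, so no step can be read between compound 3 and compound 4. The compounds shown leave open which structural change, if any, would give a readable value in this assay.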